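Swapping an Oxazole for an Oxane on the Amide

The source may hold more compounds than are shown below. What is called first, only, known or untested is meant among the compounds shown, and "the series" means these compounds.

Compound 1 `CCn1c(-c2cnc(C)nc2)nc2c(N[C@H]3CCN(C(=O)c4cocn4)C3)ncnc21` was tested in an ADME assay (Rattus norvegicus, strain Wistar Han) for metabolic stability; on this read-out lower numbers stand for a shorter-lived compound and higher numbers for a longer-lived compound; in this assay compound 1 gives 0.7 h. Going by the values given here, the only other measured compound, compound 2 `CCC(=O)N1CC[C@H](Oc2ncnc3c2nc(-c2cnc(C)nc2)n3CC)C1`, gives 1.2 h in this assay, a gap within the usual scatter, so the two stand together. Compound 3 `CCn1c(-c2cnc(C)nc2)nc2c(N[C@H]3CCN(C(=O)C4CCOCC4)C3)ncnc21` differs from compound 1 in one place: oxan-4-yl in place of 1,3-oxazol-4-yl on a carbonyl carbon. Among the compounds with values here, no measured pair shows this change, so its effect is unknown; the author expects no step beyond the scatter, with the estimated step from compound 1 to compound 3 in this assay being a 1.1-fold higher number from compound 1 to compound 3 (0.06 log units; within the scatter). For compound 3 the estimated value is 0.8 h, between 0.4 h and 1.8 h.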

Compound 3, half-life: 1.4 h
Compound 3: middle estimate off by 1.8-fold (0.24 log units), on the low side; the range from low to high includes it.
By their numbers in this assay, from the lowest: compounds 1, 2 and 3 (each within the scatter of the next).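

In this assay, going by these compounds alone, this is the first direct reading of a change on this carbonyl carbon: oxan-4-yl in place of 1,3-oxazol-4-yl gives a 2.0-fold higher number from compound 1 to compound 3 (0.30 log units; within the scatter). A five-membered aromatic ring and a six-membered non-aromatic ring can therefore be exchanged at this place without a step beyond the scatter, in this one pair. No measurement bears on why the two compounds read as they do.

Still open, going by these compounds, is whether a phenyl or cyclohexyl ring on the same carbonyl carbon would read any differently. On these data alone, it is also open whether the same exchange would give a similar step on the core of compound 2.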